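Cyclohexyl in Place of 3,5-Dimethyl-1,2-oxazol-4-yl on an Amide-Type Nitrogen

This account rests on a few compounds, and the source may have more. Where it says the series, first, only, none or still open, it means among the compounds named here.

Compound 1 `C[C@H]1C[C@H](c2nc(-c3ccc4ccccc4n3)no2)CCN1C(=O)Nc1ccccc1Cl` gives 900 nM in a functional assay on Shh Light II cells (Mus musculus) for inhibition, read by a luciferase reporter; on this read-out higher numbers stand for weaker inhibition and lower numbers for stronger inhibition.
Compound 2 `Cc1noc(C)c1NC(=O)N1CCC(c2nc(-c3ccc4ccccc4n3)no2)CC1` gives 3000 nM in this assay.
Compound 3 `Cn1c(-c2noc(C3CCN(C(=O)NC4CCS(=O)(=O)CC4)CC3)n2)nc2ccccc21` gives 350 nM in this assay.

Compound 2 stands highest of the three numbers, beyond the scatter from both compound 1 and compound 3, and is the weakest inhibitor of the set. Among the compounds with values here, no pair of measured compounds differs in a single place, so the values show only this ranking.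

Compound 4 `O=C(NC1CCCCC1)N1CCC(c2nc(-c3ccc4ccccc4n3)no2)CC1` differs from compound 2 by cyclohexyl in place of 3,5-dimethyl-1,2-oxazol-4-yl on an amide-type nitrogen. Within the data shown here, no measured step covers this exchange. A modest gain in inhibition is expected, a 2.0-fold lower number from compound 2 to compound 4 (0.30 log units; within the scatter), the other groups on that nitrogen giving lower numbers, compound 1 with 900 nM. Compound 4 is therefore estimated at 1500 nM, between 400 nM and 5000 nM.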

Compound 4, half-maximal inhibitory concentration: 57 nM
Compound 4: the middle estimate sits 26-fold (1.42 log units) above what was measured; the whole stated range lies above it.
By their numbers in this assay, from the lowest: compound 4; then compound 3; then compound 1; then compound 2.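

Within the data shown here, this is the first comparison in the set that changes a single place, and it shows that the group on the amide-type nitrogen strongly governs inhibition in this assay: cyclohexyl in place of 3,5-dimethyl-1,2-oxazol-4-yl gives a 53-fold lower number from compound 2 to compound 4 (1.72 log units; beyond the scatter). Here, a six-membered non-aromatic ring of carbon only is thus far preferred to the five-membered aromatic ring with hetero atoms. No supporting measurement accounts for the size of this step.

The compounds shown leave open whether the gain follows the loss of the aromatic ring or of its hetero atoms. Unsubstituted phenyl or tetrahydropyran-4-yl on the same nitrogen would separate the two.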